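The source may report more compounds than this note shows. Statements on the series, on what has been measured and on what is new or still open speak of the compounds shown alone.

Measured so far:

Compound 1, `Cn1c(/C=C2\SC(=O)N(CC(=O)N3CCOCC3)C2=O)nc2ccccc21` — 41100 nM
Compound 2, `CC(C)n1c(/C=C2\SC(=O)N(CC(=O)N3CCOCC3)C2=O)nc2ccccc21` — > 50000 nM
Compound 3, `COc1cc2c(cc1OC)CN(C(=O)CN1C(=O)S/C(=C\c3nc4ccccc4n3C(C)C)C1=O)CC2` — 29700 nM

All three were tested in a functional assay on DU-145 cells (Homo sapiens) for inhibition, read by MTT assay, with a stated time of 48 h; a higher number here means a weaker inhibitor, a lower number a stronger inhibitor. In this assay compound 1 gives 41100 nM and compound 3 gives 29700 nM; these two values lie within the usual scatter of each other, so neither can be called the stronger inhibitor. For compound 2 this assay reports only a limit, > 50000 nM, and not a number; this is the limit of > 50000 nM in this assay, at which 1 of the 3 values shown sits. Compound 2 and compound 1 share a core and differ in one place: methyl in place of isopropyl on an aromatic nitrogen. The step that goes with this change is an at least 1.2-fold lower number from compound 2 to compound 1 (0.08 log units; that floor lies within the scatter), so the change in this pair did not move the number by more than the scatter allows, and the limit for compound 2 leaves the true size open.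

Compound 3 carries a different core from compound 2, and the difference between the two cores is not broken down here. The compound not yet measured, compound 4, `COc1cc2c(cc1OC)CN(C(=O)CN1C(=O)S/C(=C\c3nc4ccccc4n3C)C1=O)CC2`, stands to compound 3 exactly as compound 1 stands to compound 2: methyl in place of isopropyl on an aromatic nitrogen. The place of the change is the same in both pairs, so this is the same change, made on the core of compound 3 instead of the core of compound 2. Within the data shown here, because the earlier step was an at least 1.2-fold lower number from compound 2 to compound 1 (0.08 log units; that floor lies within the scatter), the step from compound 3 to compound 4 is expected to be small as well, a 1.4-fold lower number from compound 3 to compound 4 (0.13 log units; within the scatter), since only one pair shows what this change does. Compound 4 is therefore estimated at about 22000 nM, most likely between 8000 nM and 50000 nM.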

Compound 4, half-maximal inhibitory concentration: 37500 nM
The estimate for compound 4 lay 1.7-fold (0.23 log units) below the measured number; the range from low to high includes it.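

In this assay, putting methyl in place of isopropyl on the aromatic nitrogen gives a 1.3-fold higher number from compound 3 to compound 4 (0.10 log units; within the scatter), so on the core of compound 3 this change leaves the number within what repeated measurements would scatter by. Set side by side, the two steps read: the same change on two cores in this assay, an at least 1.2-fold lower number (0.08 log units; that floor lies within the scatter) from compound 2 to compound 1 and a 1.3-fold higher number (0.10 log units; within the scatter) from compound 3 to compound 4; the limit leaves it open whether they differ This shows no step beyond the scatter on the core of compound 3, but it does not show that the change has one size on both cores, and the earlier step rests on a limit and not a number: the limit of > 50000 nM in this assay, at which 1 of the 4 values shown sits.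

The compounds shown carry only methyl and isopropyl on that nitrogen, so it stays open whether a longer chain such as n-butyl, or a chain ending in an amine or a carboxylic acid, would move the number beyond the scatter. On these data alone, it also stays open whether the change would behave the same way on cores other than these two, or in cells other than the ones used here.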